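The source may hold more compounds than are shown below. What is called first, only, known or untested is meant among the compounds shown, and "the series" means these compounds.

Measured so far:
- compound 1 `COc1ccc2c(/C=C/C(=O)c3cc(N)c(OC)c(OC)c3)c[nH]c2c1`, in a functional assay on A549 cells (Homo sapiens) for antiproliferative activity, read by MTT assay, with a stated time of 48 h; a lower number here means a stronger inhibitor, a higher number a weaker inhibitor: 193 nM
- compound 2 `COc1cc(C(=O)/C=C/c2c[nH]c3ccccc23)cc([N+](=O)[O-])c1OC`, in this assay: 1510 nM

Compound 2 stands at the higher of the two numbers; compound 1 sits at the lower number, and the gap between them is beyond the scatter. The two compounds differ in more than one place, so no single step can be read from that gap.

Compound 3 `COc1cc(C(=O)/C=C/c2c[nH]c3ccccc23)cc(N)c1OC` is the next compound, not yet measured in this assay. It is made from compound 2 by one change: amino in place of nitro on an aromatic carbon. For the measured compounds named here, no measured pair in this set shows this change on its own; the only guide is that compound 1, the compound carrying an amino group, gives 193 nM.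

For compound 3 a downward step is expected, estimated as a 3.4-fold lower number from compound 2 to compound 3 (0.53 log units; beyond the scatter), a moderate step rather than a large one. Compound 3 is expected to give about 450 nM, within a range of 150 nM to 1300 nM.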

Compound 3, half-maximal inhibitory concentration: 342 nM
Compound 3: middle estimate off by 1.3-fold (0.12 log units), on the high side; measured number inside the range.
By their numbers in this assay, from the lowest: compounds 1 and 3 (each within the scatter of the next); then compound 2.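

In this assay, amino in place of nitro on this aromatic carbon, ortho to a methoxy group, can now be read on its own: it gives a 4.4-fold lower number from compound 2 to compound 3 (0.64 log units; beyond the scatter), so this position responds to the exchange on the shared core. Hydrogen in place of methoxy, the one difference between the two amino compounds, gives a 1.8-fold higher number from compound 1 to compound 3 (0.25 log units; within the scatter), so the amino compounds are not separated by that methoxy group in this read-out. Nothing at hand accounts for the step from nitro to amino.

From the compounds shown here alone, it remains open whether the lower number belongs to amino specifically or would also appear with a hydroxyl, a methylamino or an acetamide group on this carbon. The compounds shown also leave open how a plain hydrogen at this position would compare with either the nitro or the amino group.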